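The source may hold more compounds than are shown below. What is called first, only, known or untested is meant among the compounds shown, and "the series" means these compounds.

Among the measured compounds shown here, in a functional assay on HCT-116 cells (Homo sapiens) for antiproliferative activity, read by MTT assay, with a stated time of 24 h (a higher number here means a weaker inhibitor, a lower number a stronger inhibitor), only two compounds with the shared core have been read so far. Compound 1 `COc1ccc(C(=O)/C=C/c2ccc(Br)cc2)c2c1C=CC(C)(C)O2` gives > 10000 nM, which is a limit and not a number. Compound 2 `COc1ccc(C(=O)/C=C/c2cccs2)c2c1C=CC(C)(C)O2` gives > 10000 nM, which is also a limit, so its standing rests on no measured number. Compound 3 `COc1ccc(C(=O)/C=C/c2ccc(O)cc2)c2c1C=CC(C)(C)O2` keeps the shared core and changes one group: 4-hydroxyphenyl in place of thiophen-2-yl on a double-bonded chain carbon bound to a double-bonded chain carbon. Thus 4-hydroxyphenyl takes the place of thiophen-2-yl on a double-bonded chain carbon bound to a double-bonded chain carbon. For the measured compounds named here, the only measured step that bears on this is a step that the two limits leave unreadable from compound 1 to compound 2, which exchanged 4-bromophenyl for thiophen-2-yl at that place. The evidence so far amounts to the limit of > 10000 nM in this assay, at which 2 of the 2 values shown sit. The data therefore give no size and no direction for the coming step, and no clear change is expected in this assay. A reading near that limit, or only a limit again, seems most likely. The expected change is a step that the limit leaves unreadable from compound 2 to compound 3. For compound 3 the estimated value is 12000 nM, with an expected range from 5000 nM to 30000 nM.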

Compound 3, half-maximal inhibitory concentration: > 10000 nM
Compound 3: only a limit was reported (the forecaster's own chance of this, stated with the estimate: 65%); the middle value lies beyond the limit too.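

No new step can be read among compound 1, compound 2 and compound 3: each stands only as a limit in this assay, and none gives a number. The compounds shown leave open how far these three differ from one another, and whether any group in that place gives a measured value in this assay.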